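The source may hold more compounds than are shown below. What is called first, only, known or untested is meant among the compounds shown, and "the series" means these compounds.

Measured in a functional assay on Bel-7402 cells (Homo sapiens) for inhibition, read by sulforhodamine B assay, with a stated time of 72 h; on this read-out higher numbers stand for weaker inhibition and lower numbers for stronger inhibition:
- compound 1 `C[C@H](Nc1nc(N)nc(N)c1C#N)c1nn(-c2cccc(S(C)(=O)=O)c2)c2cc(F)ccc12`: 22100 nM
- compound 2 `C[C@H](Nc1ncnc2[nH]cnc12)c1nn(-c2cccc(F)c2)c2cc(F)ccc12`: > 40000 nM
- compound 3 `C[C@H](Nc1ncnc2[nH]cnc12)c1nn(-c2ccc(C#N)cc2)c2cc(F)ccc12`: 31500 nM

Compound 2 gives > 40000 nM, which is a limit and not a number. Among the two true numbers, compound 3 at 31500 nM lies within the usual scatter of compound 1 at 22100 nM, so the two cannot be told apart.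

The next compound is compound 4 `C[C@H](Nc1ncnc2[nH]cnc12)c1nn(-c2cccc(S(C)(=O)=O)c2)c2cc(F)ccc12`, still unmeasured. Relative to compound 3, it carries 3-(methylsulfonyl)phenyl in place of 4-cyanophenyl on an aromatic nitrogen.

One measured step changes the group at this same nitrogen: an at least 1.2-fold lower number from compound 2 to compound 3 (0.10 log units; that floor lies within the scatter). It gives only a floor, and that floor lies within the scatter, so it offers no sign of a large effect from this position. Compound 1 already bears 3-(methylsulfonyl)phenyl and gives 22100 nM, but it differs from compound 4 elsewhere in the structure, so it serves only as a loose guide.

In this assay, no step beyond the scatter is expected, and no direction is favoured. The expected change is a 1.0-fold higher number from compound 3 to compound 4 (0.01 log units; within the scatter). A reading that returns only a limit also remains possible. For compound 4 the estimate is 32000 nM, with an expected range of 16000 nM to 60000 nM.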

Compound 4, half-maximal inhibitory concentration: 20000 nM
Estimate against measurement, compound 4: 1.6-fold (0.20 log units) above; the measured number falls inside the stated range.
By their numbers in this assay, from the lowest: compounds 4, 1 and 3 (each within the scatter of the next). At a limit, above all of these: compound 2.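

In this assay, the two new comparisons at the aryl group show no readable effect: exchanging the 4-cyanophenyl on the aromatic nitrogen gives a 1.6-fold lower number from compound 3 to compound 4 (0.20 log units; within the scatter), and methylsulfonyl in place of fluoro on an aromatic carbon gives an at least 2.0-fold lower number from compound 2 to compound 4 (0.30 log units; that floor lies within the scatter), so neither exchange can be called a real change. With the 3-(methylsulfonyl)phenyl now held constant, exchanging the group on the amine nitrogen gives a 1.1-fold lower number from compound 1 to compound 4 (0.04 log units; within the scatter), so compound 1 and compound 4 cannot be told apart, and this first comparison at the amine nitrogen shows no effect of that exchange. The comparison with compound 2 gives only a floor, and compound 2 itself remains a limit and not a number: the limit of > 40000 nM in this assay, at which 1 of the 4 values shown sits.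

Still open, going by these compounds, is whether a plain phenyl, or a phenyl carrying an amine or a carboxylic acid, on the aromatic nitrogen would move the number beyond the scatter. On these data alone, the fluoro on the shared core is the same in all four compounds, so the effect of chloro or hydrogen in its place also remains open.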